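The compounds below may be only part of what the source reports. "The series", "measured", "known", "first", "only" and "open" are said of these compounds alone.

Measured compounds in a functional assay on HeLa cells (Homo sapiens) for inhibition, read by sulforhodamine B assay; a higher number here means a weaker inhibitor, a lower number a stronger inhibitor:
Compound 1 `O=C1C=C(NCc2ccccc2)C(=O)c2c1nc1n2[C@H]2OC[C@@H](O)[C@H]2OC1` gives only a limit, > 8000 nM.
Compound 2 `CCOc1ccccc1NC1=CC(=O)c2c(nc3n2[C@H]2OC[C@@H](O)[C@H]2OC3)C1=O` gives 8300 nM.
Compound 3 `O=C1C(Nc2ccc(I)cc2)=CC(=O)c2c1nc1n2[C@H]2OC[C@@H](O)[C@H]2OC1` gives 4010 nM.

Compound 1 therefore stands at the edge of what this assay reports (the limit of > 8000 nM in this assay, at which 1 of the 3 values shown sits), with no number to place it against the other two. Compound 4 `O=C1C=C(Nc2ccccc2F)C(=O)c2c1nc1n2[C@H]2OC[C@@H](O)[C@H]2OC1` differs from it in one place: 2-fluorophenyl in place of benzyl on an amine nitrogen. Of the measured steps only a 2.1-fold lower number from compound 2 to compound 3 (0.32 log units; beyond the scatter) touches the group on this amine nitrogen, and it swaps one aryl for another rather than benzyl for aryl, so it bears on the present change only loosely. The two aryl amines, compound 2 and compound 3, sit in the micromolar range, and compound 4 is expected to land near them, a step of an at least 1.3-fold lower number from compound 1 to compound 4 (0.12 log units; that floor lies within the scatter). Compound 4 is estimated at 6000 nM, between 2500 nM and 16000 nM.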

Compound 4, half-maximal inhibitory concentration: 5120 nM
The estimate for compound 4 lay 1.2-fold (0.07 log units) above the measured number, and the stated range covers the measured number.
By their numbers in this assay, from the lowest: compounds 3, 4 and 2 (each within the scatter of the next, the first and the last beyond it).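

Compound 1 gives only a limit rather than a number: the limit of > 8000 nM in this assay, at which 1 of the 4 values shown sits. Replacing its benzyl with 2-fluorophenyl on the amine nitrogen gives an at least 1.5-fold lower number from compound 1 to compound 4 (0.19 log units; that floor lies within the scatter), so only a floor is known for this change, and that floor does not separate the two compounds. In this assay, compound 4 nonetheless gives a measured 5120 nM, which places this 2-fluorophenyl amine among the micromolar aryl amines. On these data alone, the true size of the benzyl-to-aryl step remains open. So does the effect on this nitrogen of a pyridyl ring, or of a phenyl ring carrying a carboxylic acid or an amine.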